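Swapping chloro for methyl on two related cores

A few compounds are considered here, and "the series" means these few. Any claim that something is new, unique, unknown or untested is made for them only; others in the source may bear on it.

compound 1 `N=c1sc(=S)[nH]c2c1cc(-c1ccc(Cl)cc1)n2-c1ccccc1`: 2%
compound 2 `Cc1ccc(-c2cc3c(=N)sc(=S)[nH]c3n2-c2ccccc2)cc1`: 0%
compound 3 `N=c1c2cc(-c3ccc(Cl)cc3)n(-c3ccccc3)c2[nH]c(=S)n1N`: 0%

In a functional assay on the whole organism for inhibition, with Rattus norvegicus as the target, read by ELISA, with stated times of 30 min and 6 h, at a dose of 30 mg/kg by the oral route (on this read-out lower numbers stand for less inhibition and higher numbers for more inhibition at the one dose given (going by the name of the read-out)), compound 1 gives 2%, compound 2 gives 0% and compound 3 gives 0%. Compound 1 and compound 2 differ in one place: methyl in place of chloro on an aromatic carbon. That change made a step of a number 2 percentage points lower from compound 1 to compound 2 (within the scatter). Compound 3 sits on another core, and how that core differs from the core of compound 1 is not broken down here. Compound 4 `Cc1ccc(-c2cc3c(=N)n(N)c(=S)[nH]c3n2-c2ccccc2)cc1` has not yet been measured; it stands to compound 3 as compound 2 stands to compound 1, the same change on the other core: methyl in place of chloro on an aromatic carbon. The step from compound 3 to compound 4 is expected to be small, no change at the digits printed from compound 3 to compound 4 (within the scatter), because the earlier step of a number 2 percentage points lower from compound 1 to compound 2 (within the scatter) stayed within the scatter. Compound 4 is therefore estimated at 0%, most likely between -6% and 8%.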

Compound 4, a percentage reported as inhibition, in the whole organism at one dose (the size of the read-out at that dose, not a potency): 0%
Compound 4: the middle estimate sits on the measured number at the digits printed; the range from low to high includes it.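

In this assay, putting 4-methylphenyl in place of 4-chlorophenyl on the second core gives no change at the digits printed from compound 3 to compound 4 (within the scatter). The change therefore reads alike on the two cores: the same change on two cores in this assay, a number 2 percentage points lower (within the scatter) from compound 1 to compound 2 and no change at the digits printed (within the scatter) from compound 3 to compound 4, 2 percentage points apart, within the scatter of two such steps. This agreement comes only from compounds showing almost no inhibition at the one dose, so it does not show that the change would behave the same way on a compound with clear inhibition, or on any further core.

The compounds shown leave open whether a different group in the same place, such as an amine, a carboxylic acid or a longer chain, would give a different result. They also leave open whether either core can give clear inhibition in this assay.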